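Swapping an ether chain in a series at its limit

This account rests on a few compounds, and the source may have more. Where it says the series, first, only, none or still open, it means among the compounds named here.

Compound 1 (`COc1ccc(C(O)C2OC(=O)c3c(OC)cc(OC)cc32)cc1`), compound 2 (`CCCOc1ccc(C(O)C2OC(=O)c3c(OC)cc(OC)cc32)cc1`) and compound 3 (`COCCCCOc1ccc(C(O)C2OC(=O)c3c(OC)cc(OC)cc32)cc1`) share one core and differ in a single chain. In an ADME assay on RAW264.7 cells (Mus musculus) for cytotoxicity, read by MTT assay, with a stated time of 24 h, in the presence of a further agent that is not named here (on this read-out higher numbers stand for weaker inhibition and lower numbers for stronger inhibition), compound 1 gives > 40000 nM, which is a limit. Compound 2 gives > 40000 nM, also a limit. Compound 3 gives > 40000 nM, again a limit and not a number. All the data so far therefore sit at one point: the limit of > 40000 nM in this assay, at which 3 of the 3 values shown sit.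

Compound 4 (`CCOCCOc1ccc(C(O)C2OC(=O)c3c(OC)cc(OC)cc32)cc1`) carries ethoxy in place of 2-methoxyethyl on a saturated chain carbon, two bonds along the chain from an oxygen on an aromatic ring.

Within the data shown here, three measured steps bear on this change: a step that the two limits leave unreadable from compound 1 to compound 2, a step that the two limits leave unreadable from compound 1 to compound 3 and a step that the two limits leave unreadable from compound 2 to compound 3. None of them has a readable size, yet each chain tried leaves the result at the limit. No step beyond the scatter is therefore expected in this assay, and no direction is expected. The expected step is a step that the limit leaves unreadable from compound 3 to compound 4. Compound 4 is estimated at 60000 nM, with an expected range of 30000 nM to 120000 nM.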

Compound 4, half-maximal inhibitory concentration: > 40000 nM
Compound 4 gave a limit, no number; the forecaster's own chance of this, stated with the estimate: 90%; the middle value is on the limit's open side.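

Compound 4 gives > 40000 nM in this assay, a limit and not a number. Among these compounds, no step to compound 4 from compound 1, compound 2 or compound 3 can be read. The compounds shown leave open whether any ether chain on the shared core gives a numerical value in this assay.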